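The compounds below may be only part of what the source reports. "The series", "measured", "known", "first", "only" and "open" are said of these compounds alone.

In an ADME assay on ECV-304 cells (Homo sapiens) for cytotoxicity, read by MTT assay, with a stated time of 72 h (on this read-out lower numbers stand for stronger inhibition and higher numbers for weaker inhibition), compound 2 (`COc1ccc(C2=C(c3cc(OC)c(OC)c(OC)c3)C(=O)C(O)C2)cc1Cl`) gives 20 ug/mL as the higher of the two actual numbers in this small set. In the same test compound 3 (`COc1ccc(C2=C(c3cc(OC)c(OC)c(OC)c3)C(=O)C(OC(C)=O)C2)cc1Cl`) gives 3.5 ug/mL and so sits lower. The measured move between them is a 5.7-fold lower number from compound 2 to compound 3 (0.76 log units; beyond the scatter) with acetyl in place of hydrogen on an oxygen on a saturated carbon. In this assay compound 1 (`COc1ccc(C2=C(c3cc(OC)c(OC)c(OC)c3)C(=O)C(OC(C)=O)C2)cc1OC(C)C`) reaches only a limit of > 100 ug/mL and no number.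

Compound 4 (`COc1ccc(C2=C(c3cc(OC)c(OC)c(OC)c3)C(=O)C(O)C2)cc1OC(C)C`) has not yet been measured. It departs from compound 2 in a single place ortho to a methoxy group, with isopropoxy in place of chloro on an aromatic carbon as the counted difference. Among the measured compounds shown here, the one measured step at this position is the same exchange in the opposite direction, with chloro in place of isopropoxy giving an at least 28-fold lower number from compound 1 to compound 3 (1.45 log units; beyond the scatter) in the acetyl pair. Read in reverse, this large step points to a large rise in this assay toward a higher number, although it rests on that single pair. The estimate means a 6.0-fold higher number from compound 2 to compound 4 (0.78 log units; beyond the scatter) as the expected step. Compound 4 is expected at about 120 ug/mL with an estimated range from 50 ug/mL to 400 ug/mL and is expected perhaps to reach only a limit.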

Compound 4, half-maximal inhibitory concentration: > 100 ug/mL
Compound 4 gave a limit, no number (the forecaster's own chance of this, stated with the estimate: 65%); the middle value is on the limit's open side.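

In this assay, the exchange at this position now has a direction in the pair without the acetyl group as well, with isopropoxy in place of chloro giving an at least 5.0-fold higher number from compound 2 to compound 4 (0.69 log units; beyond the scatter). The change on an aromatic carbon ortho to a methoxy group therefore runs the same way in both pairs, though the sizes of the two steps cannot be set against each other: the same change on two cores in this assay, an at least 28-fold lower number (1.45 log units; beyond the scatter) from compound 1 to compound 3 and an at least 5.0-fold lower number (0.69 log units; beyond the scatter) from compound 4 to compound 2; the limit leaves it open whether they differ. Compound 1 and compound 4 both stand at a limit, the step between them cannot be read, and the acetyl change keeps a measured size only between the two chloro compounds: the limit of > 100 ug/mL in this assay, at which 2 of the 4 values shown sit.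

The compounds shown leave open what the actual numbers of compound 1 and compound 4 are, and so whether isopropoxy costs more in one pair than in the other. They also leave open whether an amine or a longer alkoxy chain on this aromatic carbon would read like chloro or like isopropoxy in this assay.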